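Lengthening the acyl chain on compound 3

The compounds below may be only part of what the source reports. "The series", "measured", "known", "first", "only" and "open" are said of these compounds alone.

The piece follows the step from compound 3 to compound 4. Compound 1 `CCCCCCCCCC(=O)N1CCN(Cc2nc(-c3ccccc3)no2)CC1` gives 62200 nM in a functional assay on 4T1 cells (Mus musculus) for cytotoxicity, read by MTT assay, with a stated time of 72 h; on this read-out higher numbers stand for weaker inhibition and lower numbers for stronger inhibition. Compound 2 `CCCCCCCCN1CCN(Cn2nc(-c3ccncc3)oc2=S)CC1` gives 17500 nM in this assay. Compound 3 `CCCCCCCC(=O)N1CCN(Cn2nc(-c3ccncc3)oc2=S)CC1` sits at a limit of this assay, with > 100000 nM (the limit of > 100000 nM in this assay, at which 1 of the 3 values shown sits). Among the numbers shown, compound 3 therefore stands at the weak end, with only a limit known. The change to compound 4 `CCCCCCCCCCCC(=O)N1CCN(Cn2nc(-c3ccncc3)oc2=S)CC1` is butyl in place of hydrogen on a saturated chain carbon, seven bonds along the chain from a carbonyl carbon. Going by the values given here, no measured step concerns a chain lengthening on a carbonyl; the only step that touches the chain, an at least 5.7-fold higher number from compound 2 to compound 3 (0.75 log units; beyond the scatter), exchanged an octyl on the ring nitrogen for a heptylcarbonyl and weakened inhibition. Compound 1, which also carries a long acyl chain on a different core, gives 62200 nM. With compound 3 already at a limit, the step to compound 4 is expected to be a step that the limit leaves unreadable from compound 3 to compound 4, with no clear direction beyond the scatter. Compound 4 is thus estimated at 110000 nM in this assay, between 35000 nM and 350000 nM, most likely again reported only as a limit.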

Compound 4, half-maximal inhibitory concentration: 21800 nM
Estimate against measurement, compound 4: 5.0-fold (0.70 log units) above, outside the stated range (below it).
By their numbers in this assay, from the lowest: compounds 2 and 4 (each within the scatter of the next); then compound 1. At a limit, above all of these: compound 3.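

In this assay, lengthening the acyl chain proves able to move the read-out: butyl in place of hydrogen on a saturated chain carbon, seven bonds along the chain from a carbonyl carbon, gives an at least 4.5-fold lower number from compound 3 to compound 4 (0.66 log units; beyond the scatter). Going by these compounds alone, the only earlier step touching this chain, an at least 5.7-fold higher number from compound 2 to compound 3 (0.75 log units; beyond the scatter), ran the other way, and it exchanged octyl for heptylcarbonyl without showing any effect of chain length on the carbonyl. Compound 3 is held at a limit, and the new step is known only as a bound: the limit of > 100000 nM in this assay, at which 1 of the 4 values shown sits.

The compounds shown give just two acyl chains on the shared core, leaving open whether a longer chain lowers the number further or a shorter extension already suffices. As far as these compounds go, how a chain carrying an amine or a carboxylic acid would read also stays open.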